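Nitro for methoxy on the aryl of compound 3

The source may report more compounds than this note shows. Statements on the series, on what has been measured and on what is new or still open speak of the compounds shown alone.

Compound 3 `COc1ccc(C2CC(c3ccc(NC(=O)c4cc(Cl)ccc4OC)cc3)=NN2c2ccccc2)cc1` gives 94.8% in a functional assay on the whole organism (strain albino) with Rattus norvegicus as the target, read by paw edema, with stated times of 1 h and 4 h, at a dose of 25 mg/kg by the oral route (a higher number here means a stronger effect of the compound at the dose given, a lower number a weaker effect), the largest read-out among the three measured compounds. Compound 2 `COc1ccc(C2CC(c3ccc(NC(=O)c4cc(Cl)ccc4OC)cc3)=NN2C)cc1` gives 88.1%, which lies within the scatter of compound 3, and compound 1 `COc1ccc(/C=C/C(=O)c2ccc(NC(=O)c3cc(Cl)ccc3OC)cc2)cc1` gives 79%, beyond the scatter below compound 3. Going by the values given here, the one single-point step in the measured set, a number 6.7 percentage points higher from compound 2 to compound 3 (within the scatter), concerns phenyl in place of methyl on an amine nitrogen in a ring and does not touch the aromatic substituent changed here.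

Compound 4 `COc1ccc(Cl)cc1C(=O)Nc1ccc(C2=NN(c3ccccc3)C(c3ccc([N+](=O)[O-])cc3)C2)cc1` differs from compound 3 as follows: nitro in place of methoxy on an aromatic carbon. Among the compounds with values here, no measured pair reports a nitro for a methoxy on an aromatic carbon, so nothing sizes this change; the only stated step, from compound 2 to compound 3, lay within the scatter. The expectation for compound 4 is therefore a step of a number 4.8 percentage points lower from compound 3 to compound 4 (within the scatter), no change beyond the scatter. Compound 4 is estimated at 90%, expected between 75% and 98%.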

Compound 4, a percentage reported as activity, at one dose (the size of the read-out at that dose, not a potency): 90.9%
Beside the measured number, compound 4's estimate is 0.9 percentage points below it, and the stated range covers the measured number.
By their numbers in this assay, from the lowest: compounds 1, 2, 4 and 3 (each within the scatter of the next, the first and the last beyond it).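

In this assay, nitro in place of methoxy on this aromatic carbon gives a number 3.9 percentage points lower from compound 3 to compound 4 (within the scatter), and this is the only pair shown that sizes a change at this position, para to a large group. With phenyl kept on the amine nitrogen in the ring, the read-out at this dose therefore does not depend on methoxy at this position, since 4-nitrophenyl serves as well as 4-methoxyphenyl within the scatter. No measurement available gives a reason for this result.

Still open, on these data alone, is how an amine, a carboxylic acid or a longer alkoxy chain at this position would read, and whether nitro gives the same result with methyl on the ring nitrogen. As far as these compounds go, a read-out at one dose is not a potency, so any difference that a dose series might reveal also remains open.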